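The compounds below may be only part of what the source reports. "The series", "measured", "known", "first", "only" and "open" are said of these compounds alone.

Measured compounds in the series:
- compound 1 `CC(C)C[C@]1(O)NC(=O)[C@]2(OC(Cc3ccccc3)=CC2=O)[C@H]1O`
- compound 2 `Cc1cc2c(c(=O)[nH]1)OC(C(=O)CC(C)C)O2`
- compound 3 `CC1=CC(=O)[C@]2(O[C@@H]2C(=O)CC(C)C)C(=O)N1`

In a functional assay on HCT-116 cells (Homo sapiens) for cytotoxicity, read by WST assay, with a stated time of 48 h (on this read-out lower numbers stand for stronger inhibition and higher numbers for weaker inhibition), compound 1 gives > 100000 nM, a limit of the assay and not a number. In this assay compound 2 likewise gives > 100000 nM, again a limit rather than a number. For compound 3 this assay records only "not determined" (no result reported), so its place among the others cannot be fixed from a number of its own; what is known of the set is only that (the limit of > 100000 nM in this assay, at which 2 of the 3 values shown sit).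

The step considered next leads from compound 3 to compound 4 `CC1=CC(=O)C2(OC2C(=O)CC(C)C)C(=O)N1`. Compared by structure, the change is the two compounds have the same atoms and bonds; at least one stereo element is drawn with a configuration in one of them and without one in the other: 2 of 2 stereo elements differ; a stereocentre at a saturated ring carbon is drawn S in compound 3 and without a configuration in compound 4; a stereocentre at a saturated ring carbon is drawn S in compound 3 and without a configuration in compound 4. The same atoms and bonds are present in both; compound 4 is drawn without the two configurations that compound 3 carries, so compound 4 may stand for the same material or for a mixture of its stereoisomers.

Going by the values given here, no measured step in this assay exists between any two compounds here, and compound 3 itself has no number, so no size or direction for the change can be read from the data. Given that two of the three recorded values sit at the limit, the expectation for compound 4 in this assay is an inactive result: estimated 100000 nM, with a range of 30000 nM to 300000 nM, and most likely reported only as a limit.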

Compound 4, half-maximal inhibitory concentration: 30400 nM
Beside the measured number, compound 4's estimate is 3.3-fold (0.52 log units) above it; low and high end bracket the measured number.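

In this assay, going by these compounds alone, compound 4 gives 30400 nM and compound 3 has no number of its own, so no step between compound 3 and compound 4 can be read. Still open, from the compounds shown here alone, is whether compound 4 stands for the same material as compound 3 or a mixture of stereoisomers, and whether the drawn configurations bear on cytotoxicity.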